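Working notes: 3-methoxyphenyl in place of isopropyl

The compounds below may be only part of what the source reports. "The series", "measured", "known", "first", "only" and "open" are said of these compounds alone.

The series shares one core. Compound 1 is `Cc1ccnnc1N1CCN(c2ncccn2)CC1` and compound 2 is `Cc1cc(C(C)C)nnc1N1CCN(c2ncccn2)CC1`, and both have been measured in a functional assay on BV-2 cells (Mus musculus) for inhibition, read by ELISA, with a stated time of 16 h; a lower number here means a stronger inhibitor, a higher number a weaker inhibitor. In this assay compound 1 gives > 100000 nM, which is a limit of the assay and not a number. In this assay compound 2 gives > 100000 nM, again a limit rather than a number. The step that the two limits leave unreadable from compound 1 to compound 2 therefore cannot be read. Compound 2 thus stands at the limit of > 100000 nM in this assay, at which 2 of the 2 values shown sit, and no reading within the series separates it from compound 1.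

Compound 3 is `COc1cccc(-c2cc(C)c(N3CCN(c4ncccn4)CC3)nn2)c1`. It differs from compound 2 as follows: 3-methoxyphenyl in place of isopropyl on an aromatic carbon. Among the compounds with values here, the only measured step, a step that the two limits leave unreadable from compound 1 to compound 2, touches the same aromatic carbon, but with both of its ends sitting at the limit its size is unknown, so nothing measured bears readably on the new change. For compound 3 in this assay the expected step is a number no higher from compound 2 to compound 3 (the limit leaves the size open), itself uncertain, with the assay most likely again reporting a limit. The estimate for compound 3 in this assay is 100000 nM, with a range from 15000 nM to 600000 nM.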

Compound 3, half-maximal inhibitory concentration: 2600 nM
The estimate for compound 3 lay 38-fold (1.59 log units) above the measured number; measured number below the stated range.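

Within the data shown here, this aromatic carbon, next to the ring nitrogen, is the first place where a change gives a readable number in this assay: 3-methoxyphenyl in place of isopropyl gives an at least 38-fold lower number from compound 2 to compound 3 (1.58 log units; beyond the scatter), and 3-methoxyphenyl in place of hydrogen gives an at least 38-fold lower number from compound 1 to compound 3 (1.58 log units; beyond the scatter). The position therefore tolerates a group of 8 heavy atoms and responds to what is placed there, but the entering group differs from isopropyl at once in its size, its six-membered aromatic ring of carbon only and its hydrogen-bond acceptor, and the step cannot separate these. Both steps are lower bounds on the true size, and the two earlier compounds share a limit of the assay rather than a number: the limit of > 100000 nM in this assay, at which 2 of the 3 values shown sit.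

As far as these compounds go, whether the methoxy group is needed at all, or an unsubstituted phenyl would give a similar number, remains open, as does the effect of moving the methoxy group to another place on the phenyl ring. Also open, from the compounds shown here alone, is how this carbon would respond to a group of another kind, such as an amine, a carboxylic acid or a longer alkyl chain.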